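A few compounds are considered here, and "the series" means these few. Any claim that something is new, unique, unknown or untested is made for them only; others in the source may bear on it.

Working notes on the series. In a functional assay on UV4 cells (Cricetulus griseus) for cytotoxicity, with a stated time of 4 h (a lower number here means a stronger inhibitor, a higher number a weaker inhibitor), compound 1 `CNc1ccc2c(c1)N(S(C)(=O)=O)CC2CCl` gives 4100 nM, and compound 2 `CS(=O)(=O)N1CC(CCl)c2ccc(S)cc21` gives 124000 nM. Of the two numbers compound 2 holds the higher one; the nearest is compound 1, and the step of a 30-fold higher number from compound 1 to compound 2 (1.48 log units; beyond the scatter) carries the change of sulfanyl in place of methylamino on an aromatic carbon.

Compound 3 `CSSc1ccc2c(c1)N(S(C)(=O)=O)CC2CCl` is not yet measured. It differs from compound 2 by methylsulfanyl in place of hydrogen on a sulfur whose other neighbour is an aromatic carbon, so the sulfanyl of compound 2 becomes a (methylsulfanyl)sulfanyl. For the measured compounds named here, no measured step touches a change on this sulfur; the only step on record, from compound 1 to compound 2, swaps the whole group at the aromatic carbon and says nothing about capping the sulfur. The expectation for compound 3 in this assay therefore rests on compound 2 alone, with a wide range and no step beyond the scatter claimed with any confidence, as a 2.1-fold lower number from compound 2 to compound 3 (0.32 log units; beyond the scatter). The estimate for compound 3 is 60000 nM, between 8000 nM and 300000 nM.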

Compound 3, half-maximal inhibitory concentration: > 50000 nM
Compound 3: no number, only a limit; the forecaster's own chance of this, stated with the estimate: 10%; the middle value is on the limit's open side.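

In this assay, the result for compound 3 is a limit of the assay and not a number: the limit of > 50000 nM in this assay, at which 1 of the 3 values shown sits. For the compounds shown here, the step between compound 2 and compound 3 cannot be read, so capping the sulfur with methylsulfanyl has no measurable size so far. The new information lies at the aromatic carbon: (methylsulfanyl)sulfanyl in place of methylamino gives an at least 12-fold higher number from compound 1 to compound 3 (1.08 log units; beyond the scatter), so a second sulfur-linked group, after the sulfanyl of compound 2, also stands beyond the scatter on the weaker side of compound 1.

As far as these compounds go, whether compound 3 truly differs from compound 2 stays open. Also open, from the compounds shown here alone, is how an unsubstituted amine, a longer chain on the nitrogen such as ethylamino, or a carboxylic acid on this aromatic carbon would compare with the methylamino of compound 1.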